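A few compounds are considered here, and "the series" means these few. Any claim that something is new, unique, unknown or untested is made for them only; others in the source may bear on it.

Among the measured compounds shown here, in a functional assay on DU-145 cells (Homo sapiens) for cytotoxicity, read by sulforhodamine B assay, with a stated time of 48 h (a lower number here means a stronger inhibitor of growth, a higher number a weaker inhibitor of growth), compound 2 `CCN1CCN(c2nc(Nc3ccc(C#N)c(C(F)(F)F)c3)nc(Oc3ccnc4ccccc34)n2)CC1` gives 86600 nM, the only number among the three values shown. Compound 1 `N#Cc1ccc(Nc2nc(Oc3ccnc4ccccc34)nc(N3CCN(c4ccc(F)cc4)CC3)n2)cc1C(F)(F)F` gives > 100000 nM, which is a limit of the assay. Compound 3 `N#Cc1ccc(Nc2nc(Oc3ccnc4ccccc34)nc(N3CCC(Cc4ccccc4)CC3)n2)cc1C(F)(F)F` gives > 100000 nM, also a limit. Two of the three values thus sit at the limit of > 100000 nM in this assay, at which 2 of the 3 values shown sit. Compound 4 `N#Cc1ccc(Nc2nc(Oc3ccnc4ccccc34)nc(N3CCN(Cc4ccccc4)CC3)n2)cc1C(F)(F)F` differs from compound 2 by phenyl in place of methyl on a saturated chain carbon bound to an amine nitrogen in a ring. For the measured compounds named here, the one measured step that bears on a change at this part of the shared core is an at least 1.1-fold lower number from compound 1 to compound 2 (0.06 log units; that floor lies within the scatter), a move whose floor lies within the scatter. Compound 3 also bears a benzyl group, but no step to it is shown and its value is a limit. Going by the values given here, with the single relevant step giving no resolved change, compound 4 is expected to show no shift beyond the scatter, an estimated step of a 1.2-fold higher number from compound 2 to compound 4 (0.06 log units; within the scatter). Compound 4 is therefore estimated at 100000 nM, within a range from 45000 nM to 220000 nM, with a real chance that this assay again reports only a limit.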

Compound 4, concentration for 50% growth inhibition: > 100000 nM
Compound 4: only a limit was reported; the forecaster's own chance of this, stated with the estimate: 55%; the middle value sits exactly at the limit.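

Replacing the ethyl of compound 2 with benzyl on the amine nitrogen in the ring gives, in this assay, an at least 1.1-fold higher number from compound 2 to compound 4 (0.06 log units; that floor lies within the scatter), so this change shows no shift that can be told from the scatter. The step between compound 1 and compound 4 cannot be read, as both values are limits. Benzyl on this nitrogen thus joins 4-fluorophenyl and leaves compound 2 as the only compound with a number, and the series now sits mostly at one boundary: the limit of > 100000 nM in this assay, at which 3 of the 4 values shown sit.

Whether any group on this amine nitrogen can move growth inhibition beyond the scatter stays open, and the compounds shown give no real number for benzyl or 4-fluorophenyl. A plain hydrogen, a methyl, or a longer chain ending in an amine or a carboxylic acid at this nitrogen is not among the compounds shown.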